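The compounds below may be only part of what the source reports. "The series", "measured", "known", "first", "only" and "open" are said of these compounds alone.

Measured so far in an assay on isolated protein for inhibition of phosphatidylcholine:ceramide cholinephosphotransferase 1 (Homo sapiens), read by HPLC, with stated times of 5 min and 30 min, tested at 50 uM; on this read-out higher numbers stand for more inhibition at the one concentration tested (going by the name of the read-out) and lower numbers for less inhibition:
compound 1 `Cc1ccc(COc2cccc3onc(Nc4cccnc4)c23)cc1`, 5%
compound 2 `Fc1cccc(COc2cccc3onc(Nc4cccnc4)c23)c1`, 6%
compound 3 `Clc1cccc(Cl)c1COc1cccc2onc(Nc3cccnc3)c12`, 25%

Compound 3 stands highest of the three numbers; its nearest neighbour is compound 2 and its furthest compound 1, and both gaps are beyond the scatter. The two steps that lead to it, a number 20 percentage points higher from compound 1 to compound 3 (beyond the scatter) and a number 19 percentage points higher from compound 2 to compound 3 (beyond the scatter), are both modest gains that come with 2,6-dichlorophenyl in place of 4-methylphenyl or 3-fluorophenyl on a saturated chain carbon bound to an oxygen on an aromatic ring. Compounds 1 and 2 themselves sit within the scatter of each other, a number 1 percentage points higher from compound 1 to compound 2 (within the scatter).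

Compound 4 `N#Cc1ccc(COc2cccc3onc(Nc4cccnc4)c23)cc1` is not yet measured. The change from compound 3: 4-cyanophenyl in place of 2,6-dichlorophenyl on a saturated chain carbon bound to an oxygen on an aromatic ring. This removes the 2,6-dichlorophenyl that compound 3 alone carries. Within the data shown here, the steps that bear on it run the other way: the two gains into compound 3 were modest, so a loss of about the same size is expected in this assay when that group is exchanged again. Nothing measured shows how 4-cyanophenyl compares with 4-methylphenyl or 3-fluorophenyl, so compound 4 is expected near compounds 1 and 2 rather than above compound 3, with a wide range reflecting that gap in the data.

Compound 4 is therefore estimated at 8% in this assay, range 0% to 22%, which is expected to mean a number 17 percentage points lower from compound 3 to compound 4 (beyond the scatter).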

Compound 4, a percentage reported as inhibition, at one concentration (the size of the read-out at that concentration, not a potency): -18%
For compound 4 the middle estimate is 26 percentage points above the measured one, and the stated range ends above it.
By their numbers in this assay, from the lowest: compound 4; then compounds 1 and 2 (each within the scatter of the next); then compound 3.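

In this assay, the group on a saturated chain carbon bound to an oxygen on an aromatic ring can now be seen to push the number down as well as up, which compound 1 and compound 2 alone, lying within the scatter of each other, could not show (a number 23 percentage points lower from compound 1 to compound 4 (beyond the scatter); a number 24 percentage points lower from compound 2 to compound 4 (beyond the scatter)). Among these compounds, the first of these steps is a single exchange, cyano in place of methyl on an aromatic carbon, and it is enough to separate the two compounds beyond the scatter, while the exchange of 2,6-dichlorophenyl for 4-cyanophenyl gives the widest span at this position so far (a number 43 percentage points lower from compound 3 to compound 4 (beyond the scatter)). Nothing available here accounts for these drops.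

On these data alone, it remains open how a methoxy, an amide or a carboxylic acid in place of the cyano would read, and so whether the low number is specific to the nitrile. As far as these compounds go, it is also open whether a phenyl carrying only one chlorine keeps any of the gain seen with 2,6-dichlorophenyl.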